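The source may hold more compounds than are shown below. What is called first, only, known or untested is meant among the compounds shown, and "the series" means these compounds.

Among the compounds with values here, the three compounds measured so far share a core in which a hydroxamic acid chain hangs from an unsaturated lactam, and they differ only in the group carried on the lactam nitrogen. Within the data shown here, compound 1 `COc1cccc(CN2CC=C(CCC(=O)NO)C2=O)c1` bears a benzyl group with a methoxy on its aromatic ring; in a functional assay on HCT-15 cells (Homo sapiens) for antiproliferative activity (a higher number here means a weaker inhibitor of growth, a lower number a stronger inhibitor of growth), compound 1 gives 2820 nM, the only outright number in the set. Compound 2 `COc1cccc(CCCN2CC=C(CCC(=O)NO)C2=O)c1`, which has a longer linker between the aromatic ring and the lactam nitrogen, reaches only the limit of this assay, with compound 2 giving > 10000 nM. Compound 3 `COc1ccc(CCCN2CC=C(CCC(=O)NO)C2=O)cc1`, a positional isomer of compound 2 with the same longer linker, also stops at the limit, compound 3 giving > 10000 nM. So compound 1 stands alone as a fixed point, with the limit of > 10000 nM in this assay, at which 2 of the 3 values shown sit, marking where the other two sit.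

Compound 4 `O=C(CCC1=CCN(Cc2ccccc2)C1=O)NO` has not yet been measured. It differs from compound 1 by hydrogen in place of methoxy on an aromatic carbon, with the benzyl linker of compound 1 kept. Among the measured compounds shown here, no measured pair isolates this change, since compounds 2 and 3 alter the linker as well. The step from compound 1 to compound 4 is therefore expected to be small, at most a modest weakening, as a 1.2-fold higher number from compound 1 to compound 4 (0.09 log units; within the scatter). Compound 4 is estimated at 3500 nM, within a range of 1500 nM to 9000 nM.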

Compound 4, concentration for 50% growth inhibition: 5370 nM
The estimate for compound 4 lay 1.5-fold (0.19 log units) below the measured number, within the range that was stated.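

Taking the methoxy off the aromatic ring while the benzyl linker stays in place isolates a single change for the first time, and in this assay it gives a 1.9-fold higher number from compound 1 to compound 4 (0.28 log units; within the scatter). At this place, on an aromatic carbon meta to a large group, hydrogen can therefore stand in for methoxy without a difference beyond the usual scatter, even though the change removes 2 heavy atoms and 1 hydrogen-bond acceptor. Compound 4 joins compound 1 as a second outright number, while the other values remain a limit rather than numbers: the limit of > 10000 nM in this assay, at which 2 of the 4 values shown sit.

What the compounds shown leave open is whether a different group at this same place, such as an amine, a carboxylic acid or a fluorine atom, would move the number beyond the scatter, given that only methoxy and hydrogen can be compared here. They also leave open whether a methoxy on another carbon of the ring would behave in the same way on the benzyl linker, and how a ring without methoxy would read on a longer chain.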